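Removing the para nitro group from a trimethoxybenzoyl aminothiophene

The compounds below may be only part of what the source reports. "The series", "measured", "known", "first", "only" and "open" are said of these compounds alone.

Of the compounds shown here, three sharing one core have been measured in a functional assay on CCRF-CEM cells (Homo sapiens) for antiproliferative activity; on this read-out higher numbers stand for weaker inhibition and lower numbers for stronger inhibition. Compound 1 `COc1cc(C(=O)c2sc(-c3ccc(C)cc3)cc2N)cc(OC)c1OC` gives 15 nM, compound 2 `COc1cc(C(=O)c2sc(-c3ccc(C(F)(F)F)cc3)cc2N)cc(OC)c1OC` gives 270 nM, and compound 3 `COc1cc(C(=O)c2sc(-c3ccc([N+](=O)[O-])cc3)cc2N)cc(OC)c1OC` gives 99 nM. On these numbers compound 3 stands second highest: the step of a 6.6-fold higher number from compound 1 to compound 3 (0.82 log units; beyond the scatter) is modest, while a 2.7-fold lower number from compound 2 to compound 3 (0.44 log units; beyond the scatter) is also modest, and the largest gap is an 18-fold higher number from compound 1 to compound 2 (1.26 log units; beyond the scatter).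

Compound 4 `COc1cc(C(=O)c2sc(-c3ccccc3)cc2N)cc(OC)c1OC` differs from compound 3 by hydrogen in place of nitro on an aromatic carbon, the same difference read one bond further out being 4-nitrophenyl to phenyl. Among the compounds with values here, no measured step replaces a group with hydrogen on this aromatic carbon, so the bearing steps are indirect: the nitro compound sits between the methyl compound and the trifluoromethyl compound, and the change from methyl to nitro cost the modest step of a 6.6-fold higher number from compound 1 to compound 3 (0.82 log units; beyond the scatter). Because compound 1 gives 15 nM, the estimate is that taking the nitro away moves the number back toward that value, so a modest lower step a 2.8-fold lower number from compound 3 to compound 4 (0.45 log units; beyond the scatter) is expected. Compound 4 is therefore estimated at 35 nM, with a range from 10 nM to 120 nM.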

Compound 4, half-maximal inhibitory concentration: 4.5 nM
Beside the measured number, compound 4's estimate is 7.8-fold (0.89 log units) above it; measured number outside the range, below it.
By their numbers in this assay, from the lowest: compound 4; then compound 1; then compound 3; then compound 2.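

In this assay hydrogen gives the lowest number of the four compounds, and each of the three groups tried on this aromatic carbon stands beyond the scatter from it: nitro to hydrogen is the step (a 22-fold lower number from compound 3 to compound 4 (1.34 log units; beyond the scatter)), trifluoromethyl to hydrogen is the step (a 60-fold lower number from compound 2 to compound 4 (1.78 log units; beyond the scatter)), and methyl to hydrogen is the step (a 3.3-fold lower number from compound 1 to compound 4 (0.52 log units; beyond the scatter)). Methyl, the best of the first three, is therefore itself a cost, though a smaller one than nitro or trifluoromethyl, and in this set no group at this position improves on hydrogen. Nothing at hand accounts for this order.

Going by these compounds, whether a fluorine, a methoxy or an amine on this carbon would match compound 4 stays open. So does whether hydrogen would keep its lead with the amine of the shared core replaced.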